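The source may report more compounds than this note shows. Statements on the series, on what has been measured and on what is new or still open speak of the compounds shown alone.

Notes on the tetrabromobenzotriazole series. Compound 1 `OC(CCn1nc2c(Br)c(Br)c(Br)c(Br)c2n1)c1ccc(F)cc1` gives 110% in a functional assay on CCRF-CEM cells (Homo sapiens) for antiproliferative activity, read by MTT assay, with a stated time of 24 h, tested at 12.5 uM; on this read-out higher numbers stand for a weaker effect at the one concentration tested and lower numbers for a stronger effect. Compound 2 `OC(CCn1nc2c(Br)c(Br)c(Br)c(Br)c2n1)c1cccc(Cl)c1` gives 110% in this assay, and compound 3 `C[C@@H](O)CCn1nc2c(Br)c(Br)c(Br)c(Br)c2n1` gives 88%. Compound 1 is level with compound 2 at the digits read, and the two sit together at the top of the three numbers; compound 3 reads lower, beyond the scatter. Among the measured compounds shown here, the one step within the set, no change at the digits printed from compound 1 to compound 2 (within the scatter), shows that swapping the aryl group leaves the read-out unchanged. Compound 4 `OC(CCn1nc2c(Br)c(Br)c(Br)c(Br)c2n1)c1ccccc1` differs from compound 1 by hydrogen in place of fluoro on an aromatic carbon. For the measured compounds named here, the aryl swap from compound 1 to compound 2 is the only bearing step, and it gave no change, so compound 4 is expected to show no movement beyond the scatter, a step of a number 2 percentage points lower from compound 1 to compound 4 (within the scatter). Compound 4 is therefore estimated at 108%, within 94% to 122%.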

Compound 4, a percentage reported as activity, at one concentration (the size of the read-out at that concentration, not a potency): 122%
The estimate for compound 4 lay 14 percentage points below the measured number; measured number inside the range.
By their numbers in this assay, from the lowest: compound 3; then compounds 1 and 2 (each within the scatter of the next); then compound 4.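

Taking the halogen off the aryl ring moves the read-out towards a weaker effect: a number 12 percentage points higher from compound 1 to compound 4 (beyond the scatter) and a number 12 percentage points higher from compound 2 to compound 4 (beyond the scatter). The swap between the two halogenated aryl groups gave no such movement, so here the phenyl of compound 4 stands apart from both halogenated rings. Nothing shown gives a reason for this step. Open, from the compounds shown here alone, is whether a methoxy group or an amine in place of the halogen would read with compound 1 or with compound 4.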